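Adding a methyl to the amine of compound 1

The source may hold more compounds than are shown below. What is called first, only, known or untested is meant among the compounds shown, and "the series" means these compounds.

compound 1 `C=C(c1ccc(OC)cc1NC(=O)CNC)c1ccc(OC)c2c1C=CC(C)(C)O2` gives 720 nM
compound 2 `C=C(c1ccc(OC)cc1NC(=O)CNCC)c1ccc(OC)c2c1OC(C)(C)C=C2` gives 1030 nM
compound 3 `C=C(c1cc(OC)c(OC)c(OC)c1)c1ccc(OC)cc1NC(=O)CNCC` gives 450 nM

In a functional assay on A2780 cells (Homo sapiens) for antiproliferative activity, read by MTT assay, with a stated time of 48 h (on this read-out lower numbers stand for stronger inhibition and higher numbers for weaker inhibition), the value of compound 1 lies within the usual scatter of both compound 2 and compound 3, so these numbers do not set it apart from either of them. The next compound to be tested is compound 4 `C=C(c1ccc(OC)cc1NC(=O)CN(C)C)c1ccc(OC)c2c1C=CC(C)(C)O2` which differs from compound 1 by one change: methyl in place of hydrogen on an amine nitrogen that is, methyl in place of hydrogen on an amine nitrogen. Among the compounds with values here, no measured pair shows this change on its own. The expectation therefore rests on how close compound 1 (720 nM) stands to compound 2 (1030 nM) and to compound 3 (450 nM) even though both of those carry a different amine side chain. No step beyond the scatter is expected, and these data favour no direction. An expected 1.1-fold higher number from compound 1 to compound 4 (0.05 log units; within the scatter) stays within the scatter. The estimate for compound 4 is 800 nM with an expected range from 300 nM to 2100 nM on this read-out.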

Compound 4, half-maximal inhibitory concentration: 670 nM
For compound 4 the middle estimate is 1.2-fold (0.08 log units) above the measured one, within the range that was stated.
By their numbers in this assay, from the lowest: compounds 3, 4, 1 and 2 (each within the scatter of the next, the first and the last beyond it).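

In this assay, within the data shown here, methyl in place of hydrogen on an amine nitrogen gives a 1.1-fold lower number from compound 1 to compound 4 (0.03 log units; within the scatter) and is the first single change at this position that can be read on its own. On the core of compound 1, methylamino and dimethylamino therefore cannot be told apart on this read-out, and compound 4 shows that antiproliferative activity of this order persists when this nitrogen carries no hydrogen. Nothing in the information given explains this outcome.

The compounds shown leave open whether this nitrogen would accept something larger than methyl or ethyl, such as a propyl chain or a ring amine like pyrrolidine or morpholine, and how a primary amine would compare. They also leave open whether the same methyl step would read alike on the core of compound 3.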